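The source may hold more compounds than are shown below. What is called first, only, known or untested is meant among the compounds shown, and "the series" means these compounds.

Measured compounds:
- Compound 1 `Cc1cc(OCCCCCCC[N+]2(C)CCCC2)cc(-n2cc(C(=O)Nc3cc(F)cc(F)c3)c(=O)c3ccc(N(C)C)nc32)c1`: in an assay on LX2 cells for inhibition of COL1A1 promoter (Homo sapiens), read by a luciferase reporter, with a stated time of 24 h, tested at 50 uM (on this read-out lower numbers stand for a weaker effect and higher numbers for a stronger effect at the one concentration tested), compound 1 gives 35.4%.
- Compound 2 `CC[N+]1(CCCCCCCOc2cc(C)cc(-n3cc(C(=O)Nc4cc(F)cc(F)c4)c(=O)c4ccc(N(C)C)nc43)c2)CCCCC1`: in this assay compound 2 gives 86.6%.

Compound 2 stands highest of the two numbers; compound 1 sits a large step lower, a number 51.2 percentage points higher from compound 1 to compound 2 (beyond the scatter). Compound 3 `CC[N+]1(CCCCCCCOc2cc(C)cc(-n3cc(C(=O)Nc4cc(F)cc(F)c4)c(=O)c4ccc(N(C)C)nc43)c2)CCCC1` differs from compound 2 in one place: a group of 7 heavy atoms (6 carbon, 1 nitrogen; one five-membered non-aromatic ring with 1 hetero atom) in place of a group of 8 heavy atoms (7 carbon, 1 nitrogen; one six-membered non-aromatic ring with 1 hetero atom), on a saturated chain carbon, seven bonds along the chain from an oxygen on an aromatic ring. Among the measured compounds shown here, the only measured step that bears on this is a number 51.2 percentage points higher from compound 1 to compound 2 (beyond the scatter), which also swapped a five-membered ring for a six-membered ring, though with two heavy atoms added rather than one removed, so it is not an exact mirror of the change from compound 2 to compound 3. Compound 3 returns to a five-membered ring, so a partial reversal of that gain is expected, a drop in this assay that is beyond the scatter but smaller than the measured step. Compound 3 is therefore estimated at 60%, with a range of 35% to 85%, an expected step of a number 26.6 percentage points lower from compound 2 to compound 3 (beyond the scatter).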

Compound 3, a percentage reported as inhibition, at one concentration (the size of the read-out at that concentration, not a potency): 73.2%
Compound 3: the middle estimate sits 13.2 percentage points below what was measured; the range from low to high includes it.
By their numbers in this assay, from the lowest: compound 1; then compound 3; then compound 2.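

In this assay, methyl in place of hydrogen on the saturated chain carbon bound to the ring amine nitrogen gives a number 37.8 percentage points higher from compound 1 to compound 3 (beyond the scatter), with the five-membered non-aromatic ring held constant. With that methyl kept, the five-membered ring in place of the six-membered ring gives a number 13.4 percentage points lower from compound 2 to compound 3 (beyond the scatter), so the earlier step, which changed both features at once, now separates into a large part tied to the added methyl and a modest part tied to ring size. No measured evidence accounts for either change.

Going by these compounds, whether a propyl group on the ring nitrogen would extend the gain remains open. So does whether a seven-membered ring or a morpholine ring would continue the ring-size trend seen across compound 2 and compound 3.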